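Shortening the ether of compound 1: what to expect

A few compounds are considered here, and "the series" means these few. Any claim that something is new, unique, unknown or untested is made for them only; others in the source may bear on it.

compound 1 `CCCCO[C@H](c1ccc(O)c(O)c1)[C@H](CC#Cc1ccc(O)c(O)c1)O[C@@H]1O[C@H](CO)[C@@H](O)[C@H](O)[C@H]1O` — 95.4%
compound 2 `CCCCO[C@@H](c1ccc(O)c(O)c1)[C@H](CC#Cc1ccc(O)c(O)c1)O[C@@H]1O[C@H](CO)[C@@H](O)[C@H](O)[C@H]1O` — 96.8%

In a functional assay on heart right ventricle (Rattus norvegicus, strain WKY), tested at 10 uM (a higher number here means a weaker effect of the compound at the concentration tested, a lower number a stronger effect), compound 1 gives 95.4%, and compound 2 gives 96.8%; the step of a number 1.4 percentage points higher from compound 1 to compound 2 (within the scatter) lies within the scatter, so the two stand together near the top of the scale. Compound 3 `CO[C@H](c1ccc(O)c(O)c1)[C@H](CC#Cc1ccc(O)c(O)c1)O[C@@H]1O[C@H](CO)[C@@H](O)[C@H](O)[C@H]1O` differs from compound 1 by hydrogen in place of propyl on a saturated chain carbon bound to an oxygen on a saturated carbon. Among the compounds with values here, no measured step touches this change; the only measured step concerns configuration alone. The expected step is therefore a number 0.4 percentage points lower from compound 1 to compound 3 (within the scatter), nothing beyond the scatter. Compound 3 is estimated at 95%, with a range of 82% to 104%.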

Compound 3, a percentage reported as activity, at one concentration (the size of the read-out at that concentration, not a potency): 104%
Compound 3: the middle estimate sits 9 percentage points below what was measured; the measured number falls inside the stated range.
By their numbers in this assay, from the lowest: compounds 1, 2 and 3 (each within the scatter of the next).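

Shortening butoxy to methoxy is the first change of group at this place shown here, and in this assay it gives a number 8.6 percentage points higher from compound 1 to compound 3 (within the scatter). Removing propyl from this saturated chain carbon therefore leaves the read-out without a step beyond the scatter, so the ether's length, from butoxy to methoxy, does not separate these two compounds. Nothing available bears on a reason for this step.

Still open, on these data alone, is whether a longer chain than butyl, or an amine or a carboxylic acid in place of the ether, would give a step beyond the scatter.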